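Chain Amine in Place of a Terminal Alkyne Carbon

The source may hold more compounds than are shown below. What is called first, only, known or untested is meant among the compounds shown, and "the series" means these compounds.

Among the compounds with values here, compound 1 `C#CCCCCOc1ccc2ccc(=O)oc2c1` is the weaker of the two compounds measured so far in an assay on cells for inhibition of Amine oxidase [flavin-containing] A (Homo sapiens), read by Amplex Red, with stated times of 30 min and 45 min (a higher number here means a weaker inhibitor, a lower number a stronger inhibitor), where compound 1 gives 367 nM. Within the data shown here, its only measured neighbour is compound 2 `C#CCCCCOc1ccc2c(C)cc(=O)oc2c1`, which in this assay gives 59.9 nM; the difference between them is a single methyl in place of hydrogen on an aromatic carbon, and the step is a 6.1-fold lower number from compound 1 to compound 2 (0.79 log units; beyond the scatter).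

Compound 3 `C#CCNCCOc1ccc2ccc(=O)oc2c1` keeps the core and the substituted aromatic carbon of compound 1 unchanged; the change is propargylamino in place of but-3-yn-1-yl on a saturated chain carbon, two bonds along the chain from an oxygen on an aromatic ring. Among the measured compounds shown here, none of the measured steps touches this chain: the step from compound 1 to compound 2 sits on the aromatic ring and says nothing about what a nitrogen in the chain does. So the expectation rests on compound 1 alone, and with no comparable step to lean on, the sensible expectation is a step to a somewhat higher number with a wide range. Compound 3 is therefore expected to give about 900 nM in this assay, between 250 nM and 4000 nM, an estimated step of a 2.5-fold higher number from compound 1 to compound 3 (0.39 log units; beyond the scatter).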

Compound 3, half-maximal inhibitory concentration: 10000 nM
For compound 3 the middle estimate is 11-fold (1.05 log units) below the measured one; measured number above the stated range.
By their numbers in this assay, from the lowest: compound 2; then compound 1; then compound 3.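

In this assay, within the data shown here, the chain proves to matter more than the earlier compounds could show: propargylamino in place of but-3-yn-1-yl, on a saturated chain carbon, two bonds along the chain from an oxygen on an aromatic ring, gives a 27-fold higher number from compound 1 to compound 3 (1.44 log units; beyond the scatter), a large step that leaves the core untouched. The two groups match in their 4 heavy atoms and in their triple bond outside aromatic rings, so this step comes with no change in those counts; what enters is 1 nitrogen in place of a carbon, along with 1 hydrogen-bond donor and 1 hydrogen-bond acceptor. Nothing given here accounts for the size of this step.

The compounds shown leave open whether the higher number belongs to the nitrogen as such or would also come with an ether oxygen at the same place in the chain, or with a tertiary amine carrying a methyl on that nitrogen. They also leave open whether methyl in place of hydrogen on the aromatic carbon, which gave a 6.1-fold lower number from compound 1 to compound 2 (0.79 log units; beyond the scatter) with the all-carbon chain, would lower the number by a similar amount with the propargylamino chain.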